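Ethoxy for Methoxy on the Compound with the Highest Number of Three

The source may hold more compounds than are shown below. What is called first, only, known or untested is meant among the compounds shown, and "the series" means these compounds.

Compound 1 `COc1ccc(C=C2C(=O)OC(C)(C)OC2=O)cc1`: 9.26%
Compound 2 `COc1cc(OC)c(OC)cc1C=C1C(=O)OC(C)(C)OC1=O`: 9.86%
Compound 3 `COc1cc(C=C2C(=O)OC(C)(C)OC2=O)ccc1O`: 92.6%

These three values come from a functional assay, with a stated time of 12 h, tested at 100 uM; a lower number here means less inhibition, a higher number more inhibition at the concentration tested (going by the name of the read-out). Compound 3 stands highest of the three, and its gap to compound 2 and to compound 1 is well beyond the scatter of this assay, so its number in this assay is clearly the highest of the set. Compound 4 `CCOc1cc(C=C2C(=O)OC(C)(C)OC2=O)ccc1O` differs from compound 3 in one place: methyl in place of hydrogen on a saturated chain carbon bound to an oxygen on an aromatic ring. Among the measured compounds shown here, no measured pair of compounds shows the effect of this change, so the expectation rests on the small size of the change alone. A small step is expected, downward if anything, probably within or only slightly beyond the scatter: the step from compound 3 to compound 4 is estimated at a number 10.6 percentage points lower from compound 3 to compound 4 (beyond the scatter). Compound 4 is therefore expected to give 82%, in the range from 55% to 97%.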

Compound 4, a percentage reported as inhibition, at one concentration (the size of the read-out at that concentration, not a potency): 95.6%
Estimate against measurement, compound 4: 13.6 percentage points below; measured number inside the range.
By their numbers in this assay, from the lowest: compounds 1 and 2 (each within the scatter of the next); then compounds 3 and 4 (each within the scatter of the next).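

Methoxy to ethoxy is the first single change that can be read in this assay: the step is a number 3 percentage points higher from compound 3 to compound 4 (within the scatter), so compound 3 and compound 4 cannot be told apart here. This position therefore accepts one added methyl, on a saturated chain carbon bound to an oxygen on an aromatic ring, with no loss beyond the scatter. Nothing available explains this result.

On these data alone, whether a longer chain, such as propoxy or butoxy, would fare the same remains open. So does the effect of an amine or a carboxylic acid at the end of this chain.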